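A few compounds are considered here, and "the series" means these few. Any claim that something is new, unique, unknown or untested is made for them only; others in the source may bear on it.

Of the compounds shown here, two from this set have been measured in an assay on CHO cells for displacement of a labelled ligand from adenosine receptor A3 (Homo sapiens), read by scintillation counting, with a stated time of 120 min, tested at 10 uM (on this read-out lower numbers stand for less inhibition and higher numbers for more inhibition at the one concentration tested (going by the name of the read-out)), so far. Compound 1 `Nc1scc(CN2CCN(c3ccccc3C(F)(F)F)CC2)c1C(=O)c1ccc(Cl)cc1` gives 0% in this assay, and compound 2 `Nc1scc(CN2CCC(c3ccc(Cl)cc3)CC2)c1C(=O)c1ccc(Cl)cc1` gives 6%. The gap between the two values lies within the scatter of repeated measurements, so nothing separates compound 1 from compound 2 on these numbers; both sit at the bottom of the scale, showing essentially no inhibition at the single concentration tested. Going by the values given here, no pair of measured compounds here differs in only one place, so no measured step is available to lean on.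

Compound 3 `Nc1scc(CN2CCN(c3cc(F)ccc3F)CC2)c1C(=O)c1ccc(Cl)cc1` is the compound still to be measured. It differs from compound 1 in one place: 2,5-difluorophenyl in place of 2-(trifluoromethyl)phenyl on an amine nitrogen in a ring. Both measured compounds show almost nothing in this assay, and compound 3 keeps the shared core of compound 1 unchanged apart from this group, so the step from compound 1 is expected to be none beyond the scatter, a number 3 percentage points higher from compound 1 to compound 3 (within the scatter). Compound 3 is therefore estimated to give 3% in this assay, within a range of -8% to 15%.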

Compound 3, a percentage reported as inhibition, at one concentration (the size of the read-out at that concentration, not a potency): 2%
The estimate for compound 3 lay 1 percentage points above the measured number, and the stated range covers the measured number.
By their numbers in this assay, from the lowest: compounds 1, 3 and 2 (each within the scatter of the next).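

In this assay, the exchange of 2-(trifluoromethyl)phenyl for 2,5-difluorophenyl on an amine nitrogen in a ring gives a number 2 percentage points higher from compound 1 to compound 3 (within the scatter), the first step measured at this position. The two groups differ in their fluorine count and in size, 10 heavy atoms against 8, yet this change leaves the read-out indistinguishable, and both compounds stay at the bottom of the scale at the single concentration tested, so the step shows no sign that this position responds to an exchange between these two fluorinated phenyl groups. No measurement at hand offers an explanation for this flat result.

Going by these compounds, both groups are fluorinated phenyl rings with no hydrogen-bond donors or acceptors, so it remains open whether a phenyl ring carrying a methoxy group or a carboxylic acid on this same nitrogen would lift the number above the scatter. It also remains open whether any compound built on this shared core reaches a clear inhibition in this assay, since the compounds shown offer no reference point higher on the scale.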